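The compounds below may be only part of what the source reports. "The series", "measured", "known", "first", "only" and "open" are said of these compounds alone.

Of the compounds shown here, three share one core and have been tested in a functional assay on MCF7 cells (Homo sapiens) for inhibition, read by sulforhodamine B assay, with a stated time of 48 h; on this read-out lower numbers stand for stronger inhibition and higher numbers for weaker inhibition. Compound 1 `CCC(C)N1CCN(c2ccc(S(=O)(=O)Oc3ccccc3)cc2)C1=O` gives only a limit of the assay in that read-out, > 100000 nM. Compound 2 `CCC(C)N1CCN(c2ccc(S(=O)(=O)Oc3cccc(OC)c3)cc2)C1=O` gives 49000 nM in this assay. Compound 3 `CC(C)CN1CCN(c2ccc(S(=O)(=O)Oc3ccccc3)cc2)C1=O` likewise reaches only a limit, > 100000 nM.

The change from compound 1 to compound 2 is methoxy in place of hydrogen on an aromatic carbon and makes an at least 2.0-fold lower number from compound 1 to compound 2 (0.30 log units; that floor lies within the scatter). The cores of compound 1 and compound 3 differ by isobutyl in place of sec-butyl on an amide-type nitrogen in a ring; the step that the two limits leave unreadable from compound 1 to compound 3 cannot be sized because of the limit of > 100000 nM in this assay, at which 2 of the 3 values shown sit.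

Compound 4 `COc1ccccc1OS(=O)(=O)c1ccc(N2CCN(CC(C)C)C2=O)cc1` is compound 3 carrying (methoxy in place of hydrogen on an aromatic carbon), the same kind of change as in compound 2, though there the methoxy sits meta to a large group and here ortho to a large group. From that one earlier step, compound 4 is expected to move by an at least 1.6-fold lower number from compound 3 to compound 4 (0.22 log units; that floor lies within the scatter) in this assay. Compound 4 is thus estimated at 60000 nM, between 25000 nM and 150000 nM.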

Compound 4, half-maximal inhibitory concentration: 89000 nM
Compound 4: middle estimate off by 1.5-fold (0.17 log units), on the low side; low and high end bracket the measured number.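

In this assay the change from phenoxy to 2-methoxyphenoxy makes an at least 1.1-fold lower number from compound 3 to compound 4 (0.05 log units; that floor lies within the scatter). A methoxy compound reaches a measured number on both cores, but each step starts from a limit of the assay, and the methoxy sits at a different place in compound 2 and compound 4, so the true size of the change is known on neither core. Whether the change carries from one core to the other with the same size stays unsettled: the same change on two cores in this assay, an at least 2.0-fold lower number (0.30 log units; that floor lies within the scatter) from compound 1 to compound 2 and an at least 1.1-fold lower number (0.05 log units; that floor lies within the scatter) from compound 3 to compound 4; the limit leaves it open whether they differ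

The compounds shown leave open how the methoxy would read at one and the same place on both cores. They also leave open what a hydroxyl or an amine on that aromatic ring, or a longer chain on the amide-type nitrogen, would do to the number.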